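Acetamido for cyano on a second core

This account rests on a few compounds, and the source may have more. Where it says the series, first, only, none or still open, it means among the compounds named here.

Compound 1 has the structure `N#Cc1ccc(S(=O)(=O)N2C/C(=C\c3cccnc3)C(=O)/C(=C/c3ccccc3F)C2)cc1` and in a functional assay on SMMC-7721 cells (Homo sapiens) for cytotoxicity, read by MTT assay, with a stated time of 24 h (a higher number here means a weaker inhibitor, a lower number a stronger inhibitor), compound 1 gives 15400 nM. Compound 2, with the structure `CC(=O)Nc1ccc(S(=O)(=O)N2C/C(=C\c3cccnc3)C(=O)/C(=C/c3ccccc3F)C2)cc1`, differs from it by acetamido in place of cyano on an aromatic carbon, and in this assay compound 2 gives 10900 nM, so that the step is a 1.4-fold lower number from compound 1 to compound 2 (0.15 log units; within the scatter). Compound 3, with the structure `N#Cc1ccc(S(=O)(=O)N2C/C(=C\c3ccncc3)C(=O)/C(=C/c3ccccc3C(F)(F)F)C2)cc1`, rests on a different core; the difference between the two cores is not broken down here. In this assay compound 3 gives 9610 nM, a number close to those of compound 1 and compound 2. Compound 4, with the structure `CC(=O)Nc1ccc(S(=O)(=O)N2C/C(=C\c3ccncc3)C(=O)/C(=C/c3ccccc3C(F)(F)F)C2)cc1`, is not yet measured and differs from compound 3 by acetamido in place of cyano on an aromatic carbon, the same change that leads from compound 1 to compound 2. For compound 4 a step of a 1.4-fold lower number from compound 3 to compound 4 (0.14 log units; within the scatter) is expected, because the measured step of a 1.4-fold lower number from compound 1 to compound 2 (0.15 log units; within the scatter) was small and lay within the scatter. On that basis compound 4 is estimated to give 7000 nM in this assay, with the likely range between 3500 nM and 14000 nM.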

Compound 4, half-maximal inhibitory concentration: 5760 nM
The estimate for compound 4 lay 1.2-fold (0.08 log units) above the measured number, and the stated range covers the measured number.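

In this assay the replacement of cyano by acetamido gives a 1.7-fold lower number from compound 3 to compound 4 (0.22 log units; within the scatter), and set beside the earlier step it shows no difference between the two cores: the same change on two cores in this assay, a 1.4-fold lower number (0.15 log units; within the scatter) from compound 1 to compound 2 and a 1.7-fold lower number (0.22 log units; within the scatter) from compound 3 to compound 4, 1.2-fold (0.07 log units) apart, within the scatter of two such steps. Within these four compounds, then, the change carries from the core of compound 1 to the core of compound 3 with a step of similar size. Each step on its own lies within the scatter, however, so the pair does not show that acetamido lowers the number on either core, and two cores cannot show how the change would behave on a third.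

The compounds shown leave open whether a different group in this place, such as an amine, a carboxylic acid or a longer chain, would give a step beyond the scatter. They also leave open which part of the difference between the two cores, if any, could alter the size of the step.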